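The source may hold more compounds than are shown below. What is called first, only, known or untested is meant among the compounds shown, and "the series" means these compounds.

Working notes on a small set of benzothiazole-derived cytotoxicity probes.

The shared core of compound 2 `c1ccc2sc(Nc3nc4ccccc4s3)nc2c1` is carried into compound 1 `CCOc1ccc2nc(Nc3nc4ccccc4s3)sc2c1` by one change, (ethoxy in place of hydrogen on an aromatic carbon). Compound 3 `S=C(Nc1ccccc1)Nc1nc2ccccc2s1` has a different core; how the two cores differ is not broken down here. Compound 4 `CCOc1ccc2nc(NC(=S)Nc3ccccc3)sc2c1` is not yet measured and stands to compound 3 exactly as compound 1 stands to compound 2, through (ethoxy in place of hydrogen on an aromatic carbon), the same change at the same place.

In a functional assay on B16-F10 cells (Mus musculus) for cytotoxicity, read by MTT assay, with a stated time of 48 h (on this read-out lower numbers stand for stronger inhibition and higher numbers for weaker inhibition), compound 2 gives only a limit, > 50000 nM. In this assay compound 1 likewise gives a limit, > 50000 nM. The step that the two limits leave unreadable from compound 2 to compound 1 therefore cannot be read, because the limit of > 50000 nM in this assay, at which 3 of the 3 values shown sit, holds both ends of it. For compound 3 in this assay the result is again a limit, > 50000 nM, so compound 3 sits at the same edge as the other two.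

Among the measured compounds shown here, nothing in the three measured values shows any compound separating from the others, and the one repeated change has not yet produced a readable step. For compound 4 the expectation rests on compound 3 and its limit > 50000 nM together with the unreadable step that the two limits leave unreadable from compound 2 to compound 1: the step that the limit leaves unreadable from compound 3 to compound 4 is expected to be small or unreadable. Compound 4 is therefore estimated at 80000 nM in this assay, within 30000 nM to 300000 nM, most likely reported as a limit once more.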

Compound 4, half-maximal inhibitory concentration: > 50000 nM
Compound 4: no number, only a limit (the forecaster's own chance of this, stated with the estimate: 85%); the middle value lies beyond the limit too.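

Compound 4 gives > 50000 nM in this assay and this is only a limit. No new step can be read from compound 3 and compound 4, because both ends of the pair sit at one edge: the limit of > 50000 nM in this assay, at which 4 of the 4 values shown sit.

The compounds shown leave open whether ethoxy in place of hydrogen on an aromatic carbon shifts the read-out on either core, since none of them gives a number in this assay so far.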